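The compounds below may be only part of what the source reports. "The series", "measured", "known", "first", "only" and "open" are said of these compounds alone.

Series notes. Compound 1 `CN(Cc1cncnc1)S(=O)(=O)c1ccccc1Nc1cc(-c2ccc3ccn(C)c3c2)c2nccnc2c1` gives > 100000 nM in an assay on lysate for inhibition of 6-phosphofructo-2-kinase/fructose-2,6-bisphosphatase 3 (Homo sapiens), with stated times of 0.5 min and 45 min (on this read-out lower numbers stand for stronger inhibition and higher numbers for weaker inhibition), which is a limit of the assay and not a number (the limit of > 100000 nM in this assay, at which 1 of the 2 values shown sits). Among the compounds with values here, compound 2 `CNC(=O)c1ccncc1Nc1cc(-c2ccc3ccn(C)c3c2)c2nccnc2c1` holds the only measured value in this assay, where compound 2 gives 7020 nM. Within the data shown here, no step between two measured compounds is available, so nothing measured bears on the size of any change yet.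

Compound 3 `CN1CC(NC(=O)c2ccncc2Nc2cc(-c3ccc4ccn(C)c4c3)c3nccnc3c2)C1` is not yet measured in this assay. Its difference from compound 2 is: 1-methylazetidin-3-yl in place of methyl on an amide-type nitrogen. Read one bond further out, the change is methylcarbamoyl to (1-methylazetidin-3-yl)carbamoyl, on the amide-type nitrogen whose other neighbour is the carbonyl carbon. Among the measured compounds shown here, with no comparable measured step, the expected step from compound 2 to compound 3 is a 1.4-fold lower number from compound 2 to compound 3 (0.15 log units; within the scatter), which is taken as no shift beyond the usual scatter. Compound 3 is accordingly estimated at 5000 nM in this assay, with a range of 1500 nM to 16000 nM.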

Compound 3, half-maximal inhibitory concentration: 9190 nM
Estimate against measurement, compound 3: 1.8-fold (0.26 log units) below; measured number inside the range.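

In this assay, within the data shown here, the first step that can be read is a 1.3-fold higher number from compound 2 to compound 3 (0.12 log units; within the scatter), for 1-methylazetidin-3-yl in place of methyl on the amide-type nitrogen. Within this single pair, the amide-type nitrogen carries the larger group, with its four-membered ring and added nitrogen, without a shift beyond the usual scatter, so the two compounds count as equal on this read-out. Nothing available accounts for the size of this step.

One pair cannot show whether the position stays this insensitive to other groups, such as an open-chain amine like 2-(dimethylamino)ethyl or a carboxylic acid on a longer chain. Among these compounds, compound 1 differs from compound 2 and compound 3 in more than one place, so no step to either can be read.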